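This account rests on a few compounds, and the source may have more. Where it says the series, first, only, none or still open, it means among the compounds named here.

Measured in an ADME assay on HUVEC cells (Homo sapiens) for cytotoxicity, read by MTT assay, with a stated time of 48 h; a higher number here means a weaker inhibitor, a lower number a stronger inhibitor:
compound 1 `Nc1nc(-c2ccccc2)cn1/N=C/c1cc2ccccc2nc1Cl` — 46700 nM
compound 2 `Nc1nc(-c2ccc(Br)cc2)cn1/N=C/c1cc2ccccc2nc1Cl` — 11900 nM

Within the data shown here, compound 2 stands at the lowest of the two numbers in this assay; compound 1 is the only other point and sits higher by the one step recorded, a 3.9-fold lower number from compound 1 to compound 2 (0.59 log units; beyond the scatter). The next compound, compound 3 `Nc1nc(-c2cccs2)cn1/N=C/c1cc2ccccc2nc1Cl`, is not yet measured. It differs from compound 2 by thiophen-2-yl in place of 4-bromophenyl on an aromatic carbon. Among the measured compounds shown here, the only measured step that touches this part of the structure is the bromo-for-hydrogen change, a 3.9-fold lower number from compound 1 to compound 2 (0.59 log units; beyond the scatter), which was modest and beyond the scatter. Compound 3 loses the bromo entirely and replaces the six-membered ring by a five-membered one, so that step is an imperfect guide; nothing measured speaks to thiophen-2-yl itself. The number for compound 3 is expected to move back toward that of compound 1, by about a 2.5-fold higher number from compound 2 to compound 3 (0.40 log units; beyond the scatter), with wide uncertainty. Compound 3 is estimated at 30000 nM, range 12000 nM to 80000 nM.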

Compound 3, half-maximal inhibitory concentration: 10200 nM
Beside the measured number, compound 3's estimate is 2.9-fold (0.47 log units) above it; measured number below the stated range.
By their numbers in this assay, from the lowest: compounds 3 and 2 (each within the scatter of the next); then compound 1.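

At this position, on an aromatic carbon of the five-membered ring with 2 nitrogen, the bromo is not needed to reach the lower range in this assay: thiophen-2-yl in place of 4-bromophenyl gives a 1.2-fold lower number from compound 2 to compound 3 (0.07 log units; within the scatter) and leaves the two compounds unseparated. Set against the phenyl group, thiophen-2-yl gives a 4.6-fold lower number from compound 1 to compound 3 (0.66 log units; beyond the scatter) and so the step away from compound 1 is now seen with two different aromatic groups, one of them without the bromo. Nothing available explains why these two groups read alike.

Still open, as far as these compounds go, is whether the lower range extends beyond aromatic rings, for instance to a morpholine, a carboxylic acid or a longer alkyl chain at this position. From the compounds shown here alone, whether thiophen-3-yl reads like thiophen-2-yl also remains open.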